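Working notes: aryl change on the carbonyl carbon

The compounds below may be only part of what the source reports. "The series", "measured", "known", "first", "only" and "open" are said of these compounds alone.

compound 1 `COc1cc(-c2cc(/C=C/C(=O)c3ccc(Cl)c(Cl)c3)[nH]n2)cc(OC)c1OC`: 5%
compound 2 `COc1ccc(-c2cc(/C=C/C(=O)c3cc(OC)c(OC)c(OC)c3)[nH]n2)cc1OC`: -50%

In a functional assay on NCI-H23 cells (Homo sapiens) for cytotoxicity, read by sulforhodamine B assay, with a stated time of 48 h, tested at 100 uM (on this read-out higher numbers stand for a weaker effect at the one concentration tested and lower numbers for a stronger effect), compound 1 gives 5%, the highest of the two numbers. Compound 2 gives -50%, a value lower by more than the scatter, so compound 2 shows the stronger effect of the two. Compound 3 `COc1ccc(C(=O)/C=C/c2cc(-c3cc(OC)c(OC)c(OC)c3)n[nH]2)cc1OC` is not yet measured. It differs from compound 1 by 3,4-dimethoxyphenyl in place of 3,4-dichlorophenyl on a carbonyl carbon. Among the compounds with values here, no measured pair reproduces this change, so its size is uncertain. Compound 2, which carries methoxy-bearing groups at both ends, gives -50%, which argues for a stronger effect. The expected step is downward, beyond the scatter: a number 25 percentage points lower from compound 1 to compound 3 (beyond the scatter). Compound 3 is estimated at -20%, within -60% to 20%.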

Compound 3, a percentage reported as activity, at one concentration (the size of the read-out at that concentration, not a potency): -75%
Compound 3: the middle estimate sits 55 percentage points above what was measured; the whole stated range lies above it.
By their numbers in this assay, from the lowest: compound 3; then compound 2; then compound 1.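

Within the data shown here, this is the first single-place comparison, and it shows that the aryl group on the carbonyl carbon strongly affects the read-out: in this assay, 3,4-dimethoxyphenyl in place of 3,4-dichlorophenyl gives a number 80 percentage points lower from compound 1 to compound 3 (beyond the scatter), a large step. No measurement available here accounts for the step.

Still open, going by these compounds, is whether a phenyl carrying a single methoxy at this place would give a comparable step. Also open, on these data alone, is how an amine or a carboxylic acid on this aryl group would read.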